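A Methyl on the Fused Ring of an Inactive Series

The source may report more compounds than this note shows. Statements on the series, on what has been measured and on what is new or still open speak of the compounds shown alone.

Compound 1 `Cc1nnc(SCc2cc(=O)c3ccccc3o2)s1`: in a functional assay on SW480 cells (Homo sapiens) for cytotoxicity, read by MTT assay, with a stated time of 72 h (on this read-out higher numbers stand for weaker inhibition and lower numbers for stronger inhibition), compound 1 gives > 25000 nM, which is a limit of the assay.
Compound 2 `Cc1nnc(SCc2cc(=O)c3ccccc3o2)o1`: in this assay compound 2 gives > 25000 nM, again a limit of the assay.
Compound 3 `Nc1nnc(SCc2cc(=O)c3ccccc3o2)s1`: in this assay compound 3 gives > 25000 nM, also a limit of the assay.

Compound 2 therefore stands where every measured compound stands, at the limit of > 25000 nM in this assay, at which 3 of the 3 values shown sit. None of the three compounds yields a number, so the three steps between them, a step that the two limits leave unreadable from compound 1 to compound 2, a step that the two limits leave unreadable from compound 1 to compound 3 and a step that the two limits leave unreadable from compound 2 to compound 3, cannot be read in size or direction.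

Compound 4 `Cc1ccc2oc(CSc3nnc(C)o3)cc(=O)c2c1` differs from compound 2 by methyl in place of hydrogen on an aromatic carbon. For the measured compounds named here, no measured step touches this position; the only measured changes concern the group on the sulfur, and none of them moved a compound off the limit. A change of one carbon on the shared core is expected to leave compound 4 near the limit too, so the expected step from compound 2 to compound 4 is a step that the limit leaves unreadable from compound 2 to compound 4, with no shift readable beyond the scatter. Compound 4 is therefore estimated at 40000 nM, with a range from 15000 nM to 150000 nM.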

Compound 4, half-maximal inhibitory concentration: > 25000 nM
Compound 4: only a limit was reported; the forecaster's own chance of this, stated with the estimate: 85%; the middle value is on the limit's open side.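

For the compounds shown here, compound 2 and compound 4 both sit at a limit of the assay, so no step between them can be read, in size or in direction. The compounds shown leave open which change, if any, to this series would give a readable number rather than a limit.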